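The compounds below may be only part of what the source reports. "The series", "measured", "known", "first", "only" and "open" are said of these compounds alone.

Measured compounds:
- compound 1 `O=C(CN1CCN(c2cccnc2)CC1)Nc1nc2c(s1)CCCC2`: 3.3
- compound 2 `O=C(CN1CCN(c2ccccn2)CC1)Nc1nc2c(s1)CCCC2`: 3.9
- compound 3 `O=C(CN1CCN(c2nccs2)CC1)Nc1nc2c(s1)CCCC2`: 3.8

All three share one core and differ only in the group attached to the amine nitrogen in the six-membered ring. In a physicochemical assay for lipophilicity, in phosphate buffer, measured as octanol-water partition, at pH 7.4 (on this read-out higher numbers stand for higher lipophilicity and lower numbers for lower lipophilicity), compound 3 stands second highest of the three numbers: its nearest neighbour is compound 2, with a number 0.10 log units lower from compound 2 to compound 3 (within the scatter), and the furthest is compound 1, with a number 0.50 log units higher from compound 1 to compound 3 (beyond the scatter). The other measured step, a number 0.60 log units higher from compound 1 to compound 2 (beyond the scatter), is of a similar modest size.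

Compound 4 `O=C(CN1CCN(C2CCCCC2)CC1)Nc1nc2c(s1)CCCC2` is the next compound in this series. The change from compound 3 is cyclohexyl in place of 1,3-thiazol-2-yl on an amine nitrogen in a ring. Among the measured compounds shown here, none of the measured steps bears directly on this change: every step so far swaps one small aromatic ring for another, whereas here a six-membered non-aromatic ring of carbon only enters in place of a five-membered aromatic ring with two hetero atoms. The two measured steps that start at compound 1 were modest and went up, and the step between compound 2 and compound 3 stayed within the scatter, so the measured data give no firm guide to the direction here.

Compound 4 is therefore estimated with a wide range in this assay, at 2.7 (1.9 to 3.5), which is expected to mean a step of a number 1.10 log units lower from compound 3 to compound 4 (beyond the scatter).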

Compound 4, distribution coefficient: 3
Compound 4: the middle estimate sits 0.30 log units below what was measured; the measured number falls inside the stated range.
By their numbers in this assay, from the lowest: compounds 4 and 1 (each within the scatter of the next); then compounds 3 and 2 (each within the scatter of the next).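

In this assay, among the compounds shown here, cyclohexyl is the first non-aromatic ring of carbon only on this amine nitrogen, and its effect depends on which aromatic ring it replaces: it gives a number 0.80 log units lower from compound 3 to compound 4 (beyond the scatter) and a number 0.90 log units lower from compound 2 to compound 4 (beyond the scatter), but with pyridin-3-yl as the leaving group it gives a number 0.30 log units lower from compound 1 to compound 4 (within the scatter). Aromatic rings at this position therefore do not all sit on one side of the carbon-only ring, since the pyridin-3-yl compound cannot be told apart from the cyclohexyl compound on this read-out, while the other two aromatic compounds stand clearly apart from it. No measurement here explains these differences.

The compounds shown leave open whether the larger steps go with the loss of aromatic character or with the loss of hetero atoms, as cyclohexyl differs from the aromatic rings in both ways at once. A phenyl ring, which is aromatic and has only carbon in the ring, and a tetrahydropyran-4-yl ring, which is non-aromatic and holds an oxygen, could separate these two changes at this position.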